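Chloro on the Amide Ring and Cell Tolerance

This account rests on a few compounds, and the source may have more. Where it says the series, first, only, none or still open, it means among the compounds named here.

Compound 1 `CC(CSc1nnc(-c2ccncc2)s1)C(=O)Nc1c(Cl)cccc1Cl` gives > 50000 nM in an ADME assay on BHK-21 cells (Mesocricetus auratus) for cytotoxicity, with a stated time of 3 days (a lower number here means that less compound is tolerated, a higher number that more compound is tolerated), which is a limit of the assay.
Compound 3 `CC(CSc1nnc(-c2ccncc2)s1)C(=O)Nc1ccccc1Cl` gives > 50000 nM in this assay, also a limit.
Compound 2 `O=C(CCSc1nnc(-c2ccncc2)s1)NCc1ccccc1` gives 18700 nM in this assay.

Within the data shown here, compound 2 thus holds the only number; the other two values are limits. The change from compound 3 to compound 1, (chloro in place of hydrogen on an aromatic carbon), yields a step that the two limits leave unreadable from compound 3 to compound 1 because both values sit at the limit of > 50000 nM in this assay, at which 2 of the 3 values shown sit. The difference between the cores of compound 2 and compound 3 is not broken down here. Compound 4 `O=C(CCSc1nnc(-c2ccncc2)s1)NCc1ccc(Cl)cc1` carries the same kind of change, (chloro in place of hydrogen on an aromatic carbon), but the place differs: para to a large group, where compound 1 has it ortho to a large group and meta to a chloro group. Since the measured step gives no size, the step from compound 2 to compound 4 is expected to be a 1.6-fold lower number from compound 2 to compound 4 (0.19 log units; within the scatter), modest. Compound 4 is expected to give 12000 nM.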

Compound 4, half-maximal cytotoxic concentration: 21500 nM
Compound 4: middle estimate off by 1.8-fold (0.25 log units), on the low side; the measured number falls inside the stated range.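

In this assay the change from benzyl to 4-chlorobenzyl gives a 1.1-fold higher number from compound 2 to compound 4 (0.06 log units; within the scatter) and so stays within the scatter on the core of compound 2. The step from compound 3 to compound 1 cannot be read because both compounds sit at a limit of the assay: the limit of > 50000 nM in this assay, at which 2 of the 4 values shown sit. The result therefore does not show whether the chloro change carries over from one core to the other, as the core of compound 3 offers no step size to set against it.

The compounds shown leave open how an amine or a carboxylic acid in place of chloro on the benzyl ring would read in this assay. Among these compounds, they also leave open what a longer chain in place of the one in compound 2 would do.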